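From compound 3 to compound 4: working notes

The source may hold more compounds than are shown below. What is called first, only, known or untested is meant among the compounds shown, and "the series" means these compounds.

Measured so far in an ADME assay on HOS cells (Homo sapiens) for cytotoxicity, read by luminescence and ATP content, with a stated time of 48 h (on this read-out lower numbers stand for higher toxicity in this test and higher numbers for lower toxicity in this test), and shown below.
Compound 1 `Nc1c(C(=O)NCc2ccc(F)cc2F)c(=O)n(O)c2ncc(CCCC3CCCCC3)cc12` gives 27400 nM
Compound 2 `Nc1c(C(=O)NCc2ccc(F)cc2F)c(=O)n(O)c2ncc(CCc3ccccc3)cc12` gives 18000 nM
Compound 3 `Nc1c(C(=O)NCc2ccc(F)cc2F)c(=O)n(O)c2ncc(CCCOCCO)cc12` gives > 250000 nM (a limit, not a number)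

Compound 3 has only a limit in this assay, and its place on the numbers is the limit of > 250000 nM in this assay, at which 1 of the 3 values shown sits, in this short series.

Compound 4 `Nc1c(C(=O)NCc2ccc(F)cc2F)c(=O)n(O)c2ncc(/C=C/C(=O)NCCO)cc12` carries 2-((2-hydroxyethyl)carbamoyl)ethenyl in place of 3-(2-hydroxyethoxy)propyl on an aromatic carbon, with the shared core unchanged. Neither group has a ring. Going by the values given here, no measured step covers this exchange directly.

The nearest evidence is an at least 9.1-fold higher number from compound 1 to compound 3 (0.96 log units; beyond the scatter) and an at least 13-fold higher number from compound 2 to compound 3 (1.14 log units; beyond the scatter), each replacing a ring-bearing chain with a ring-free one. The step between the two ring-bearing chains is a 1.5-fold lower number from compound 1 to compound 2 (0.18 log units; within the scatter) and adds little. Among these three compounds, only the ring-free compound 3 reaches the limit, and no compound goes against that.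

With no ring entering, the expected size in this assay is small: none beyond the scatter or a modest move to a lower number, well short of an at least 13-fold higher number from compound 2 to compound 3 (1.14 log units; beyond the scatter) in size. The estimated step is an at least 1.3-fold lower number from compound 3 to compound 4 (0.14 log units; that floor lies within the scatter) in this assay. For compound 4 the estimate is 180000 nM, with an expected range of 70000 nM to 300000 nM in this assay.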

Compound 4, half-maximal cytotoxic concentration: > 250000 nM
Compound 4 was reported as a limit; the forecaster's own chance of this, stated with the estimate: 50%; at least 1.3-fold (0.14 log units) between middle value and limit.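

In this assay, the aromatic carbon two atoms from the ring nitrogen now carries a second ring-free chain, 2-((2-hydroxyethyl)carbamoyl)ethenyl, with 2 double bonds outside aromatic rings and 2 hydrogen-bond donors, and compound 4 also gives a limit rather than a number: the limit of > 250000 nM in this assay, at which 2 of the 4 values shown sit. Against the two ring-bearing chains, the change reads as an at least 13-fold higher number from compound 2 to compound 4 (1.14 log units; beyond the scatter) and an at least 9.1-fold higher number from compound 1 to compound 4 (0.96 log units; beyond the scatter), so the link between a ring-free chain and a high number in this assay no longer rests on a single chain, and none of the four compounds goes against it. The step between the two ring-free chains cannot be read, as both values are limits.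

On these data alone, how far either ring-free compound lies past the limit remains open, as does whether the ethenyl link or the carbamoyl group has any effect of its own. Also open, as far as these compounds go, is whether a ring-free chain ending in an amine or a carboxylic acid would stay at the limit, and how a ring-bearing chain ending in a hydroxyl would read.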